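The source may report more compounds than this note shows. Statements on the series, on what has been measured and on what is new or still open speak of the compounds shown alone.

Compound 1 `C=CCc1c(O)cc(O)c2c1OC(c1cccc(Br)c1)CC2=O`: 78.8%
Compound 2 `C=CCc1c(O)cc(O)c2c1OC(c1ccc(Cl)cc1)CC2=O`: 77.6%
Compound 3 `C=CCc1c(O)cc(O)c2c1OC(c1ccc(O)cc1)CC2=O`: 9.86%

All three share one core and differ only in the group carried on a saturated ring carbon. In a functional assay on aorta (Rattus norvegicus, strain Sprague-Dawley) for inhibition, with a stated time of 20 min (on this read-out lower numbers stand for smaller maximal responses and higher numbers for larger maximal responses), compound 3 stands lowest of the three numbers: its nearest neighbour is compound 2, whose value lies a number 67.7 percentage points lower from compound 2 to compound 3 (beyond the scatter) away in the opposite sense, and the furthest is compound 1, with a number 68.9 percentage points lower from compound 1 to compound 3 (beyond the scatter). The two halogen-bearing compounds sit close together, as a number 1.2 percentage points lower from compound 1 to compound 2 (within the scatter) shows.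

Compound 4 `C=CCc1c(O)ccc2c1OC(c1ccc(O)cc1)CC2=O` differs from compound 3 in one place: hydrogen in place of hydroxy on an aromatic carbon. The hydroxy that leaves sits on an aromatic carbon of the six-membered carbon ring of the fused system, para to an allyl group and meta to the remaining hydroxy group.

Among the compounds with values here, none of the measured steps touches this part of the core; each of them changes the group on the saturated ring carbon. The three steps therefore give no direct guide to the size or direction of the change in this assay, and the expectation can rest only on the value of compound 3, which carries the same 4-hydroxyphenyl group. Compound 4 is accordingly expected to give about 22%, within a broad range from 5% to 60%. This estimate means an expected step of a number 12.1 percentage points higher from compound 3 to compound 4 (beyond the scatter).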

Compound 4, largest response reached (Emax), in percent of the reference or control that the assay uses: 87.2%
For compound 4 the middle estimate is 65.2 percentage points below the measured one; measured number outside the range, above it.
By their numbers in this assay, from the lowest: compound 3; then compounds 2, 1 and 4 (each within the scatter of the next).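

In this assay, hydrogen in place of hydroxy on this aromatic carbon, para to an allyl group, gives a number 77.3 percentage points higher from compound 3 to compound 4 (beyond the scatter), so a change of a single heavy atom on the shared core moves the number by a large amount. The earlier steps shown here changed only the group on the saturated ring carbon, and they left open whether the core hydroxy mattered; now the 4-hydroxyphenyl group is seen not to give a low number on its own, since compound 3 with this hydroxy gives 9.86% and compound 4 without it gives 87.2%. Among these four compounds, the low number appears only where the 4-hydroxyphenyl group and this hydroxy occur together, and no information is available on why this hydroxy has such an effect.

As far as these compounds go, it remains open whether a methoxy group or an amine at this place would keep the number low, or whether only hydroxy does. From the compounds shown here alone, it is also open what hydrogen at this place would do in compounds carrying the 3-bromophenyl or 4-chlorophenyl group.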